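The source may report more compounds than this note shows. Statements on the series, on what has been measured and on what is new or still open speak of the compounds shown alone.

Measured compounds in the series:
- compound 1, `C[C@@H]1CN(c2sc(C(F)(F)F)nc2-c2nc3ccccc3[nH]2)CCN1C(=O)Cn1cccn1`: 191 nM
- compound 2, `C[C@@H]1CN(c2sc(C(F)(F)F)nc2-c2nc3ccccc3[nH]2)CCN1C(=O)CN1CCC(F)(F)CC1`: 2430 nM
- compound 3, `C[C@@H]1CN(c2sc(C(F)(F)F)nc2-c2nc3ccccc3[nH]2)CCN1C(=O)Cn1cnc2cccnc21`: 70 nM

In a functional assay on Venous blood for antagonist activity at C-X-C chemokine receptor type 3 (Homo sapiens), read by flow cytometry, with a stated time of 30 min, in the presence of a further agent that is not named here (a lower number here means a stronger inhibitor, a higher number a weaker inhibitor), compound 1 stands second highest of the three numbers. Its nearest neighbour is compound 3, with a 2.7-fold lower number from compound 1 to compound 3 (0.44 log units; beyond the scatter); the furthest is compound 2, with a 13-fold higher number from compound 1 to compound 2 (1.10 log units; beyond the scatter). Compound 2 and compound 3 are separated by a 35-fold lower number from compound 2 to compound 3 (1.54 log units; beyond the scatter).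

Compound 4, `C[C@@H]1CN(c2sc(C(F)(F)F)nc2-c2nc3ccccc3n2C)CCN1C(=O)Cn1cccn1`, differs from compound 1 by methyl in place of hydrogen on an aromatic nitrogen. All three measured steps change the group on the saturated chain carbon bound to the carbonyl carbon, and every measured compound keeps the 1H-benzimidazol-2-yl group unchanged. Among the compounds with values here, no measured step therefore bears on the change from compound 1 to compound 4; the series gives no direct guide to the size or direction of this step, and the chain-end steps only show that this assay can move by large amounts on a small change.

Within the data shown here, with no matching precedent, a modest loss is expected for compound 4, a 2.4-fold higher number from compound 1 to compound 4 (0.37 log units; beyond the scatter), with a wide range. Compound 4 is estimated at 450 nM, between 120 nM and 1800 nM.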

Compound 4, half-maximal inhibitory concentration: 3560 nM
The estimate for compound 4 lay 7.9-fold (0.90 log units) below the measured number; measured number above the stated range.
By their numbers in this assay, from the lowest: compound 3; then compound 1; then compounds 2 and 4 (each within the scatter of the next).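

Among the compounds shown, this is the only step outside the chain end, and in this assay methyl in place of hydrogen on the aromatic nitrogen gives a 19-fold higher number from compound 1 to compound 4 (1.27 log units; beyond the scatter). The series is therefore sensitive at the core as well as at the chain end: one added carbon, with the 1H-pyrazol-1-yl end of compound 1 left untouched, is enough for a large loss of inhibition. Nothing available explains why this change costs so much.

On these data alone, it remains open whether an ethyl group or a longer chain on this nitrogen would give a number close to that of compound 4, or whether a different result would follow. As far as these compounds go, it is also open whether 1-methyl-1H-benzimidazol-2-yl would cost as much when paired with the chain end of compound 3.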